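This account rests on a few compounds, and the source may have more. Where it says the series, first, only, none or still open, it means among the compounds named here.

Going by the values given here, compound 1 `C[C@H]1N=C2C[C@H]3C[C@H](C3(C)C)[C@@]2(C)OC1=O` is one of three compounds measured in an ADME assay on NIH3T3 cells (Mus musculus) for antiproliferative activity, read by sulforhodamine B assay, with a stated time of 48 h (a higher number here means a weaker inhibitor, a lower number a stronger inhibitor), and it gives no number there: in this assay compound 1 reaches only the limit > 1800000 nM. The two companions stand the same way. Compound 2 `CC1(C)[C@H]2CC3=N[C@H](CCC(=O)O)C(=O)O[C@]3(C)[C@@H]1C2` in this assay gives only the limit > 1200000 nM. Compound 3 `CC1(C)[C@H]2CC3=NCC(=O)O[C@]3(C)[C@@H]1C2` in this assay gives only the limit > 2000000 nM. Thus the steps from compound 1 to compound 2 a step that the two limits leave unreadable from compound 1 to compound 2, from compound 1 to compound 3 a step that the two limits leave unreadable from compound 1 to compound 3 and from compound 2 to compound 3 a step that the two limits leave unreadable from compound 2 to compound 3 cannot be sized, each pair sitting at the limit of > 1200000 nM in this assay, at which 1 of the 3 values shown sits, the limit of > 1800000 nM in this assay, at which 1 of the 3 values shown sits, or (the limit of > 2000000 nM in this assay, at which 1 of the 3 values shown sits).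

Compound 4 `C[C@@H]1N=C2C[C@@H]3C[C@@H](C3(C)C)[C@]2(C)OC1=O` differs from compound 1 as follows: the two compounds have the same atoms and bonds and differ only in configuration as drawn: 4 of 4 stereo elements differ (all stereocentres are inverted: mirror images); a stereocentre at a saturated ring carbon is drawn R in compound 1 and S in compound 4; a stereocentre at a saturated ring carbon is drawn R in compound 1 and S in compound 4; a stereocentre at a saturated ring carbon is drawn R in compound 1 and S in compound 4; a stereocentre at a saturated ring carbon is drawn R in compound 1 and S in compound 4. Among the compounds with values here, none of the measured steps bears directly on a mirror-image change, but each measured compound sits at a limit of this assay, so compound 4 is expected to behave alike, with the step from compound 1 to compound 4 estimated at a step that the limit leaves unreadable from compound 1 to compound 4. For compound 4 the estimate in this assay is 2000000 nM, within 1000000 nM to 5000000 nM, most likely reported only as a limit.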

Compound 4, half-maximal inhibitory concentration: > 2000000 nM
Compound 4: only a limit was reported; the forecaster's own chance of this, stated with the estimate: 90%; the middle value lies on the limit itself.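

In this assay, going by these compounds alone, compound 4, like compound 1, gives only a limit, so no step between compound 1 and compound 4 can be read. The compounds shown leave open whether inverting all stereocentres changes antiproliferative activity at all, and none of the four gives a number.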